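Swapping the acrylamide tail on a quinazoline-like core

The compounds below may be only part of what the source reports. "The series", "measured", "known", "first", "only" and "open" are said of these compounds alone.

Measured so far:
compound 1 `CC(C)/C=C/C(=O)Nc1cc2c(N3CCc4ccccc43)ncnc2cc1O[C@@H]1CCOC1`: 8520 nM
compound 2 `CC(C)/C=C/C(=O)Nc1cc2c(N3CCCc4ccccc43)ncnc2cc1O[C@@H]1CCOC1`: 6820 nM

Both compounds were tested in a functional assay on A549 cells (Homo sapiens) for antiproliferative activity, read by MTT assay, with a stated time of 72 h (on this read-out higher numbers stand for weaker inhibition and lower numbers for stronger inhibition), in which compound 1 gives 8520 nM and compound 2 gives 6820 nM. For the measured compounds named here, on these two numbers compound 2 stands lowest, though its only neighbour, compound 1, sits within the scatter: a 1.2-fold lower number from compound 1 to compound 2 (0.10 log units; within the scatter). That one step concerns the ring attached to the shared core and says nothing about the tail of the chain.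

Compound 3 `O=C(/C=C/CN1CCC(CO)CC1)Nc1cc2c(N3CCCc4ccccc43)ncnc2cc1O[C@@H]1CCOC1` keeps everything of compound 2 except that tail: (4-(hydroxymethyl)piperidin-1-yl)methyl in place of isopropyl on a double-bonded chain carbon bound to a double-bonded chain carbon. No measured pair differs at this position, so nothing shown here points to a step in either direction beyond the scatter. The expectation for compound 3 is therefore anchored on compound 2 with a wide band around it, amounting to a 1.4-fold lower number from compound 2 to compound 3 (0.13 log units; within the scatter). Compound 3 is thus estimated at 5000 nM in this assay, somewhere between 1200 nM and 15000 nM.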

Compound 3, half-maximal inhibitory concentration: 5300 nM
For compound 3 the middle estimate is 1.1-fold (0.03 log units) below the measured one; the measured number falls inside the stated range.
By their numbers in this assay, from the lowest: compounds 3, 2 and 1 (each within the scatter of the next).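

In this assay the tail position gets its first reading: (4-(hydroxymethyl)piperidin-1-yl)methyl in place of isopropyl gives a 1.3-fold lower number from compound 2 to compound 3 (0.11 log units; within the scatter) and so no change that can be told apart from repeat-measurement noise. For the compounds shown here, the earlier step concerned only the ring on the shared core, so this is the first sign that the number can hold steady when the chain carbon carries something quite different. The incoming group has 9 heavy atoms, a six-membered non-aromatic ring, 1 hydrogen-bond donor and 2 hydrogen-bond acceptors, against 3 heavy atoms and no ring for isopropyl, and the supporting data offer no explanation for this outcome.

Going by these compounds, this single step bundles several changes, so it remains open whether a plain piperidine without the hydroxymethyl, a morpholine or a simple dimethylamine on the same carbon would behave alike. On these data alone, it is also open whether the (4-(hydroxymethyl)piperidin-1-yl)methyl tail would give a similar result on the 2,3-dihydro-1H-indol-1-yl core of compound 1.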